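Methoxypyridinyl to cyanophenyl on the anilino nitrogen

The source may report more compounds than this note shows. Statements on the series, on what has been measured and on what is new or still open speak of the compounds shown alone.

Measured so far in a functional assay on HeLa cells (Homo sapiens) for inhibition, read by MTT assay, with a stated time of 72 h; a higher number here means a weaker inhibitor, a lower number a stronger inhibitor:
- compound 1, `CC/C=C/C(=O)Nc1cccc(Oc2nc(Nc3cccc(OC)c3)nc3ccsc23)c1`: 29400 nM
- compound 2, `COc1ccc(Nc2nc(Oc3cccc(NC(=O)C=C(C)C)c3)c3sccc3n2)cn1`: only a limit, > 100000 nM
- compound 3, `COc1ccc(Nc2nc(Oc3cccc(NC(=O)/C=C/C(C)C)c3)c3sccc3n2)cn1`: only a limit, > 50000 nM

Among the measured compounds shown here, compound 3 stands at a limit of this assay, so its place among the three cannot be fixed; compound 1 is the only one with a number. For the measured compounds named here, the single one-place step, a step that the two limits leave unreadable from compound 2 to compound 3, is unreadable, as both ends sit at limits (the limit of > 100000 nM in this assay, at which 1 of the 3 values shown sits, (the limit of > 50000 nM in this assay, at which 1 of the 3 values shown sits)).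

Compound 4, `CC(C)/C=C/C(=O)Nc1cccc(Oc2nc(Nc3cccc(C#N)c3)nc3ccsc23)c1`, differs from compound 3 by 3-cyanophenyl in place of 6-methoxypyridin-3-yl on a nitrogen on an aromatic ring. Going by the values given here, no measured step bears on this change; the only data on the anilino aryl are compound 1 with its methoxyphenyl and the two limits. The expectation therefore rests on nothing firmer than the weak range of the whole set, and a step of an at least 1.2-fold lower number from compound 3 to compound 4 (0.09 log units; that floor lies within the scatter) is expected, which is no more than a guess within the scatter. For compound 4 in this assay an estimate of 40000 nM, between 10000 nM and 100000 nM, is expected.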

Compound 4, half-maximal inhibitory concentration: 36500 nM
Estimate against measurement, compound 4: 1.1-fold (0.04 log units) above; the measured number falls inside the stated range.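

In this assay, 3-cyanophenyl in place of 6-methoxypyridin-3-yl on the anilino nitrogen gives an at least 1.3-fold lower number from compound 3 to compound 4 (0.13 log units; that floor lies within the scatter). Compound 3 gives > 50000 nM, which is a limit and not a number, so this step is only a floor: the limit of > 50000 nM in this assay, at which 1 of the 4 values shown sits. Compound 4 gives 36500 nM, so this position now carries a readable number alongside the 3-methylbut-1-en-1-yl on the carbonyl carbon, which the methoxypyridinyl compounds shown here do not provide.

The true size of the change remains open, and no step at this position is yet shown beyond the scatter. Also open, going by these compounds, is whether a phenyl bearing an amine or a carboxylic acid in place of the nitrile, or a longer chain on the carbonyl carbon, would move the number out of this weak range.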